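The source may hold more compounds than are shown below. What is called first, only, known or untested is meant among the compounds shown, and "the series" means these compounds.

Compound 1, `Cc1[nH]nc(N)c1-c1cccc(Cl)c1`: in an assay on Sf9 cells for inhibition of mitogen-activated protein kinase kinase kinase 14 (Homo sapiens), read by ADP-Glo, with a stated time of 60 min (on this read-out higher numbers stand for weaker inhibition and lower numbers for stronger inhibition), compound 1 gives > 100000 nM, which is a limit of the assay rather than a number (the limit of > 100000 nM in this assay, at which 1 of the 3 values shown sits).
Compound 2, `Cc1n[nH]c(N)c1-c1ccc(Cl)cc1`: in this assay compound 2 gives 61100 nM.
Compound 3, `CCC(=O)n1nc(C)c(-c2ccc(Cl)c(Cl)c2)c1N`: in this assay compound 3 gives 27400 nM.

Of the two real numbers, compound 3 has the lower one, and its gap to compound 2 lies beyond the usual scatter. Compound 4, `Cc1nn(C(=O)C2CCCCC2)c(N)c1-c1ccc(Cl)c(Cl)c1`, differs from compound 3 by one change: cyclohexyl in place of ethyl on a carbonyl carbon. Within the data shown here, no measured pair shows what such a change does here, so only a small step, in either direction and not clearly beyond the scatter, is expected. On that basis the step from compound 3 to compound 4 is estimated at a 1.4-fold lower number from compound 3 to compound 4 (0.14 log units; within the scatter). In this assay compound 4 is therefore expected to give about 20000 nM, most likely between 5000 nM and 80000 nM.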

Compound 4, half-maximal inhibitory concentration: 3300 nM
Beside the measured number, compound 4's estimate is 6.1-fold (0.78 log units) above it; measured number below the stated range.
By their numbers in this assay, from the lowest: compound 4; then compound 3; then compound 2. At a limit, above all of these: compound 1.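

Among these compounds, the carbonyl carbon's substituent gives the only single change that can be read so far: in this assay cyclohexyl in place of ethyl brings an 8.3-fold lower number from compound 3 to compound 4 (0.92 log units; beyond the scatter). This position is therefore sensitive to what it carries, and a carbon-only ring goes with stronger inhibition here. Nothing among the measurements shown explains why. From the compounds shown here alone, it remains open whether the ring itself matters or simply the added carbon, which a straight hexyl chain would help separate. Going by these compounds, how an amine on the ring would fare also remains open.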